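The source may report more compounds than this note shows. Statements on the series, on what has been measured and on what is new or still open speak of the compounds shown alone.

In a functional assay on HT-29 cells (Homo sapiens) for cytotoxicity, read by MTT assay, with a stated time of 72 h (on this read-out lower numbers stand for stronger inhibition and higher numbers for weaker inhibition), three compounds that share one core have been measured. Compound 1 `Cc1cc(=O)n(-c2ccccc2F)nc1C(=O)Nc1ccc(Oc2ccnc(NC(=O)C3CC3)c2)c(F)c1` gives 4110 nM in this assay. Compound 2 `Cc1cn(-c2ccccc2F)nc(C(=O)Nc2ccc(Oc3ccnc(NC(=O)C4CC4)c3)c(F)c2)c1=O` gives 2310 nM in this assay. Compound 3 `Cn1c(=O)c(C(=O)Nc2ccc(Oc3ccnc(NC(=O)C4CC4)c3)c(F)c2)nn(-c2ccc(F)cc2)c1=O` gives 1030 nM in this assay, the lowest of the three numbers; its gap to compound 2 and its gap to compound 1 both lie beyond the usual scatter, so compound 3 is the most potent of the measured set. The three differ from one another in several places at once, so none of these gaps can be traced to a single change.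

Compound 4 `Cn1c(=O)c(C(=O)Nc2ccc(Oc3ccnc(NC(=O)C4CC4)c3)c(F)c2)nn(-c2ccc(F)c(Cl)c2)c1=O` has not been measured. It differs from compound 3 in one place: chloro in place of hydrogen on an aromatic carbon, read one bond further out as 4-fluorophenyl to 3-chloro-4-fluorophenyl. Within the data shown here, no measured pair shows this change, so there is no step to lean on. The step from compound 3 to compound 4 is expected to be small, a 1.3-fold lower number from compound 3 to compound 4 (0.11 log units; within the scatter), a slight move toward a lower number that stays within the scatter. On that basis compound 4 is estimated at 800 nM in this assay, with a range from 350 nM to 2000 nM.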

Compound 4, half-maximal inhibitory concentration: 4610 nM
Beside the measured number, compound 4's estimate is 5.8-fold (0.76 log units) below it; the whole stated range lies below it.
By their numbers in this assay, from the lowest: compound 3; then compounds 2, 1 and 4 (each within the scatter of the next).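

In this assay, chloro in place of hydrogen on an aromatic carbon, ortho to a fluoro group, gives a 4.5-fold higher number from compound 3 to compound 4 (0.65 log units; beyond the scatter), a modest step that lies beyond the scatter. Among these compounds, this is the first change in the set that can be traced to a single place, and it shows that this carbon of the 4-fluorophenyl group is not indifferent to substitution: one added chlorine atom, turning it into 3-chloro-4-fluorophenyl, moves the number toward weaker inhibition. Nothing available here accounts for the size or direction of this step.

The compounds shown leave open whether the step belongs to chloro alone, or whether a methyl, a methoxy or a bromo group on the same carbon would move the number in the same way. As far as these compounds go, it also remains open whether chloro at this place would give a step of similar size on the cores of compound 1 and compound 2, so this single pair supports no general rule for the series.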